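This account rests on a few compounds, and the source may have more. Where it says the series, first, only, none or still open, it means among the compounds named here.

Measured in a physicochemical assay for solubility, in phosphate buffer, with a stated time of 18 h; a lower number here means a less soluble compound, a higher number a more soluble compound:
Compound 1 `CCCCc1nc(C(C)(C)C)nc2nc(N)c(C#N)c(N)c12` gives 6000 nM
Compound 2 `CC(C)(C)c1nc(CCCCC#N)c2c(N)c(C#N)c(N)nc2n1` gives 16000 nM
Compound 3 `CC(C)(C)c1nc(-c2cccs2)c2c(N)c(C#N)c(N)nc2n1` gives 56000 nM

Compound 3 holds the highest of the three numbers in this assay, and the other two lie clearly lower: a 3.5-fold higher number from compound 2 to compound 3 (0.54 log units; beyond the scatter) and a 9.3-fold higher number from compound 1 to compound 3 (0.97 log units; beyond the scatter). The next step leads to compound 4 `CC(C)(C)c1nc(-c2ccncc2)c2c(N)c(C#N)c(N)nc2n1`, which carries pyridin-4-yl in place of thiophen-2-yl on an aromatic carbon, opposite the ring nitrogen (pyridin-4-yl in place of thiophen-2-yl on an aromatic carbon). Among the compounds with values here, no measured step exchanges one aromatic ring for another, so the evidence is indirect. The two steps just given act at this same place, where thiophen-2-yl replaced a chain, and both were modest rises. The step that puts cyano on the chain, a 2.7-fold higher number from compound 1 to compound 2 (0.43 log units; beyond the scatter), also went up, and pyridin-4-yl likewise enters with a nitrogen where thiophen-2-yl has a sulfur. This is thin support for a further modest rise in this assay, smaller than those two steps, and a result within the scatter would be no surprise. The expected step is a 2.1-fold higher number from compound 3 to compound 4 (0.33 log units; beyond the scatter). For compound 4 the estimated value is 120000 nM, with an expected range from 40000 nM to 300000 nM.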

Compound 4, solubility: 44000 nM
For compound 4 the middle estimate is 2.7-fold (0.44 log units) above the measured one; the measured number falls inside the stated range.
By their numbers in this assay, from the lowest: compound 1; then compound 2; then compounds 4 and 3 (each within the scatter of the next).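

In this assay, this position now has its first exchange of one aromatic ring for another, and the step of a 1.3-fold lower number from compound 3 to compound 4 (0.10 log units; within the scatter) shows that pyridin-4-yl and thiophen-2-yl cannot be told apart here, even though the ring size and the hetero atom both differ. Pyridin-4-yl also stands clearly apart from both chains, with a 2.8-fold higher number from compound 2 to compound 4 (0.44 log units; beyond the scatter) against 4-cyanobutyl and a 7.3-fold higher number from compound 1 to compound 4 (0.87 log units; beyond the scatter) against butyl, so among these four compounds the clear differences at this position lie between a chain and an aromatic ring, not between the two rings, and no compound shown goes against this. Nothing available explains either why the two rings read alike or why they stand apart from the chains.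

The compounds shown leave open whether a plain phenyl ring, pyridin-2-yl or pyridin-3-yl would fall with these two rings, and whether a ring carrying an amine or a carboxylic acid would depart from them. They also leave open how a shorter chain or a chain ending in a hydroxyl group would compare at this position, and whether the exchange of rings would read the same with something other than tert-butyl on the shared core.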